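The source may hold more compounds than are shown below. What is called first, only, known or untested is meant among the compounds shown, and "the series" means these compounds.

Working notes on the series. In a functional assay on MCF7 cells (Homo sapiens) for inhibition, read by resazurin assay, with a stated time of 24 h (a higher number here means a weaker inhibitor, a lower number a stronger inhibitor), the higher of the two true numbers belongs to compound 3 `O=C1Nc2c(C(F)(F)F)cccc2C1(c1ccc(OC(F)(F)F)cc1)c1ccc(O)c(O)c1` at 49 nM. Compound 1 `O=C1Nc2c(C(F)(F)F)cccc2C1(c1ccc(O)cc1)c1ccc(OC(F)(F)F)cc1` gives 20 nM. Compound 2 `O=C1Nc2c(C(F)(F)F)cccc2C1(c1ccc(OC(F)(F)F)cc1)c1cc(F)c(O)c(F)c1` reads > 1000 nM, which is a limit of the assay.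

Compound 4 `Cc1cc(C2(c3ccc(OC(F)(F)F)cc3)C(=O)Nc3c(C(F)(F)F)cccc32)ccc1O` has methyl in place of hydroxy on an aromatic carbon, ortho to a hydroxy group and meta to a large group, the change from 3,4-dihydroxyphenyl to 4-hydroxy-3-methylphenyl: methyl in place of hydroxy on an aromatic carbon.

The step that touches this same aromatic carbon is modest: a 2.5-fold higher number from compound 1 to compound 3 (0.39 log units; beyond the scatter). The two steps that involve 3,5-difluoro-4-hydroxyphenyl are large: an at least 50-fold higher number from compound 1 to compound 2 (1.69 log units; beyond the scatter) and an at least 20-fold lower number from compound 2 to compound 3 (1.30 log units; beyond the scatter). Those large steps concern a different substitution, so they only keep the upper end of the expected range wide.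

In this assay no change beyond the scatter is expected, and the expected step is a 1.2-fold lower number from compound 3 to compound 4 (0.09 log units; within the scatter). The estimate for compound 4 is 40 nM, within an expected range of 12 nM to 200 nM.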

Compound 4, half-maximal inhibitory concentration: > 1000 nM
Compound 4 was reported as a limit (the forecaster's own chance of this, stated with the estimate: 8%); middle value at least 25-fold (1.39 log units) from the limit.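

Compound 4 reads > 1000 nM in this assay, which is a limit of the assay. For the compounds shown here, this aromatic carbon is far less tolerant than the earlier compounds suggested: methyl in place of hydroxy gives an at least 20-fold higher number from compound 3 to compound 4 (1.30 log units; beyond the scatter), and methyl in place of hydrogen gives an at least 50-fold higher number from compound 1 to compound 4 (1.69 log units; beyond the scatter), whereas hydroxy in place of hydrogen gave only a 2.5-fold higher number from compound 1 to compound 3 (0.39 log units; beyond the scatter). The true size of both methyl steps remains open: the limit of > 1000 nM in this assay, at which 2 of the 4 values shown sit.

The step from compound 2 to compound 4 cannot be read, since both values are limits. Going by these compounds, it also remains open whether a methoxy group, a chlorine or an amine on this aromatic carbon would read close to compound 1 and compound 3 or would fall with compound 4.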